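A Chain in Place of a Ring: Expecting Compound 3

A few compounds are considered here, and "the series" means these few. Any claim that something is new, unique, unknown or untested is made for them only; others in the source may bear on it.

Compound 2 `COc1cccc(-c2csc(N/N=C/c3cccs3)n2)c1` and compound 1 `COc1cccc(-c2csc(N/N=C(\C)c3cccs3)n2)c1` share a core and differ only in the group carried on the nitrogen on the aromatic ring. In an assay on isolated protein for inhibition of Amine oxidase [flavin-containing] B (Homo sapiens), read by fluorescence (on this read-out lower numbers stand for stronger inhibition and higher numbers for weaker inhibition), compound 2 gives 494 nM, and compound 1 gives 551 nM, two numbers that lie within the usual scatter of each other. Compound 3 `CCC/C(C)=N/Nc1nc(-c2cccc(OC)c2)cs1` has not yet been measured. It differs from compound 2 in one place: a group of 6 heavy atoms (5 carbon, 1 nitrogen; no ring) in place of a group of 7 heavy atoms (5 carbon, 1 nitrogen, 1 sulfur; one five-membered aromatic ring with 1 hetero atom), on a nitrogen on an aromatic ring. For the measured compounds named here, no measured step of this kind exists, so only a modest weakening is expected, a 3.0-fold higher number from compound 2 to compound 3 (0.48 log units; beyond the scatter). Compound 3 is therefore expected to give about 1500 nM in this assay, somewhere from 500 nM to 5000 nM.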

Compound 3, half-maximal inhibitory concentration: 871 nM
Compound 3: middle estimate off by 1.7-fold (0.24 log units), on the high side; the measured number falls inside the stated range.
By their numbers in this assay, from the lowest: compounds 2, 1 and 3 (each within the scatter of the next).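

In this assay, an open chain can stand in place of the aromatic ring at this position with no shift beyond the scatter. Propyl in place of thiophen-2-yl on a carbon with a double bond to nitrogen gives a 1.6-fold higher number from compound 1 to compound 3 (0.20 log units; within the scatter), and the change of the whole group on the nitrogen gives a 1.8-fold higher number from compound 2 to compound 3 (0.25 log units; within the scatter). No measured evidence explains this result. Still open, going by these compounds, is whether a longer chain, an amine or a carboxylic acid on that carbon would also leave the number within the scatter.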